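A few compounds are considered here, and "the series" means these few. Any claim that something is new, unique, unknown or untested is made for them only; others in the source may bear on it.

Working notes on the cytotoxicity series. Three members have been run in a toxicity assay on NIH3T3 cells (Mus musculus) for cytotoxicity, read by resazurin assay (a higher number here means that more compound is needed for the effect, a lower number that less compound is needed), so far. Compound 1 `CNC(=O)c1ccc(NCc2cncn2Cc2ccc(-c3ccccc3)cc2N)cc1-c1ccccc1` returns only a limit of the assay, reported as > 1000 nM. Compound 2 `Cc1cccc(-c2cccc(NCc3cncn3Cc3ccccc3)c2)c1C` likewise returns only a limit in this assay, namely > 1000 nM. Compound 3 `COC(=O)c1ccc(NCc2cncn2Cc2cccc(F)c2)cc1-c1ccccc1`, the starting point of the step followed here, also gives only a limit in this assay, > 1000 nM. Compound 3 thus stands exactly where the other two measured compounds stand: at the limit of > 1000 nM in this assay, at which 3 of the 3 values shown sit, so no number separates it from compound 1 or compound 2, and no ordering among the three can be read. Going by the values given here, no pair of measured compounds differs in a single place, so no step between measured compounds is available.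

Compound 4 `COC(=O)c1ccc(NCc2cncn2Cc2ccccc2)cc1-c1ccccc1` is the next member and has not yet been run in this assay. It differs from compound 3 by hydrogen in place of fluoro on an aromatic carbon, the rest of the structure being kept.

For this assay the step from compound 3 to compound 4 is expected to be none beyond the scatter, a step that the limit leaves unreadable from compound 3 to compound 4, because compound 3 shows > 1000 nM and nothing in the measured set points elsewhere. Compound 4 is therefore expected to give about 3000 nM in this assay, within a range of 1000 nM to 10000 nM, most likely again reported only as a limit.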

Compound 4, half-maximal effective concentration: > 1000 nM
Compound 4: a limit, no number; the forecaster's own chance of this, stated with the estimate: 85%; the middle value lies beyond the limit too.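

Compound 4 returns only a limit in this assay, > 1000 nM. No step can be read from compound 3 to compound 4, as both results are limits: the limit of > 1000 nM in this assay, at which 4 of the 4 values shown sit.

The compounds shown leave open at what concentration any of them produces the effect in this assay, and whether going from 3-fluorobenzyl to benzyl alters that concentration.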